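Swapping the aryl group again on a methoxy-bearing core

A few compounds are considered here, and "the series" means these few. Any claim that something is new, unique, unknown or untested is made for them only; others in the source may bear on it.

Measured compounds:
compound 1 `COc1ccc(/C=C/C(=O)Nc2cc3c(Nc4ccc(F)c(Cl)c4)ncnc3cc2O[C@H]2CCOC2)c(OC)c1` — 28600 nM
compound 2 `N#Cc1ccc(/C=C/C(=O)Nc2cc3c(Nc4ccc(F)c(Cl)c4)ncnc3cc2O[C@H]2CCOC2)cc1` — 9830 nM
compound 3 `COc1ccc(/C=C/C(=O)Nc2cc3c(Nc4ccc(F)c(Cl)c4)ncnc3cc2OC)c(OC)c1` — 36600 nM

In a functional assay on MCF7 cells (Homo sapiens) for cytotoxicity, read by MTT assay, with a stated time of 72 h (a higher number here means a weaker inhibitor, a lower number a stronger inhibitor), compound 1 gives 28600 nM, compound 2 gives 9830 nM and compound 3 gives 36600 nM. Compound 2 differs from compound 1 by 4-cyanophenyl in place of 2,4-dimethoxyphenyl on a double-bonded chain carbon bound to a double-bonded chain carbon. This change gave a 2.9-fold lower number from compound 1 to compound 2 (0.46 log units; beyond the scatter). Compound 3 differs from compound 1 by methyl in place of oxolan-3-yl on an oxygen on an aromatic ring; this gave a 1.3-fold higher number from compound 1 to compound 3 (0.11 log units; within the scatter), so the two cores sit within the scatter of each other.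

Compound 4 `COc1cc2ncnc(Nc3ccc(F)c(Cl)c3)c2cc1NC(=O)/C=C/c1ccc(C#N)cc1` has not yet been measured in this assay. It differs from compound 3 by 4-cyanophenyl in place of 2,4-dimethoxyphenyl on a double-bonded chain carbon bound to a double-bonded chain carbon, which is the same change, at the same place, that turned compound 1 into compound 2. The expectation rests on that earlier step, which gave a 2.9-fold lower number from compound 1 to compound 2 (0.46 log units; beyond the scatter), and on the two cores standing within the scatter of each other. Compound 4 is therefore expected to show a 2.9-fold lower number from compound 3 to compound 4 (0.46 log units; beyond the scatter). The estimate for compound 4 in this assay is 12600 nM, expected to fall between 6000 nM and 26000 nM.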

Compound 4, half-maximal inhibitory concentration: "not active" (no number reported)
For compound 4 the study gives words and no number; there is nothing to compare the estimate with.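

In this assay, among the compounds shown here, compound 4 is reported only in words, as not active, so no step from compound 3 to compound 4 can be read. On these data alone, whether 4-cyanophenyl in place of 2,4-dimethoxyphenyl acts alike on the two cores stays open. Nothing available bears on this result.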